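A few compounds are considered here, and "the series" means these few. Any claim that something is new, unique, unknown or untested is made for them only; others in the source may bear on it.

Measured compounds:
compound 1 `NC(=O)c1c(NC(=O)c2ccc(C(F)(F)F)cc2)sc2c1CCN(Cc1c(Cl)cccc1Cl)C2`: a limit of the assay, > 50000 nM
compound 2 `NC(=O)c1c(NC(=O)c2ccccc2I)sc2c1CCN(C(=S)Nc1ccccc1Cl)C2`: a limit of the assay, > 50000 nM
compound 3 `Cc1ccccc1C(=O)Nc1sc2c(c1C(N)=O)CCN(C(=S)Nc1ccccc1Cl)C2`: 35300 nM

All three were run in a functional assay on HeLa cells (Homo sapiens) for antiproliferative activity, with a stated time of 24 h; on this read-out lower numbers stand for stronger inhibition and higher numbers for weaker inhibition. Within the data shown here, compound 3 holds the only actual number in the set; the other two results are limits, and compound 3 itself sits in the weak range. Among the measured compounds shown here, the one measured step, an at least 1.4-fold lower number from compound 2 to compound 3 (0.15 log units; that floor lies within the scatter), is within the scatter, and its starting point is a limit, so it gives little guidance. Compound 4 `NC(=O)c1c(NC(=O)c2ccc(C(F)(F)F)cc2)sc2c1CCN(C(=S)Nc1ccccc1Cl)C2` is not yet measured; it differs from compound 3 by 4-(trifluoromethyl)phenyl in place of 2-methylphenyl on a carbonyl carbon. Compound 1 carries the same 4-(trifluoromethyl)phenyl amide and returns a limit, so the step is expected to be a 1.7-fold higher number from compound 3 to compound 4 (0.23 log units; within the scatter), most likely ending in a limit. Compound 4 is estimated at 60000 nM (25000 nM to 150000 nM).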

Compound 4, half-maximal inhibitory concentration: 44000 nM
Compound 4: the middle estimate sits 1.4-fold (0.13 log units) above what was measured, and the stated range covers the measured number.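

In this assay, the step at the carbonyl carbon can now be read between two actual numbers: a 1.2-fold higher number from compound 3 to compound 4 (0.10 log units; within the scatter). Exchanging 2-methylphenyl for 4-(trifluoromethyl)phenyl at this place therefore leaves the result within the scatter, and both compounds remain in the weak range. The other two steps, an at least 1.1-fold lower number from compound 2 to compound 4 (0.05 log units; that floor lies within the scatter) and an at least 1.1-fold lower number from compound 1 to compound 4 (0.05 log units; that floor lies within the scatter), cannot be read, because each starts from a limit of the assay: the limit of > 50000 nM in this assay, at which 2 of the 4 values shown sit.

On these data alone, whether an aminophenyl or a carboxylic acid-bearing phenyl on this carbonyl carbon would move the number beyond the scatter remains open. The effect of the group on the ring amine nitrogen also remains unresolved.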